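Sulfonylcarbamoyl substituents on the core of compound 1

The compounds below may be only part of what the source reports. "The series", "measured", "known", "first", "only" and "open" are said of these compounds alone.

Measured so far:
compound 1 `O=C(COc1ccc(Oc2ccccc2)cc1)Cn1ncc2ccccc21` — 2600 nM
compound 2 `O=C(COc1ccc(Oc2ccccc2)cc1)Cn1ncc2cc(C(=O)NS(=O)(=O)c3ccccc3)ccc21` — 4700 nM

Among the measured compounds shown here, in an assay on microsomes from brain for inhibition of Fatty-acid amide hydrolase 1 (Rattus norvegicus), read by fluorescence and HPLC, with a stated time of 45 min (a lower number here means a stronger inhibitor, a higher number a weaker inhibitor), compound 1 gives 2600 nM, the lowest of the two numbers; the only neighbour is a 1.8-fold higher number from compound 1 to compound 2 (0.26 log units; within the scatter), so the two compounds cannot be separated. Compound 3 `O=C(COc1ccc(Oc2ccccc2)cc1)Cn1ncc2cc(C(=O)NS(=O)(=O)C(F)(F)F)ccc21` differs from compound 1 as follows: ((trifluoromethyl)sulfonyl)carbamoyl in place of hydrogen on an aromatic carbon. For the measured compounds named here, the one measured step that bears on this change is the (phenylsulfonyl)carbamoyl step, a 1.8-fold higher number from compound 1 to compound 2 (0.26 log units; within the scatter), which left the number within the scatter of the unsubstituted parent. Nothing in the data distinguishes a trifluoromethyl from a phenyl on the sulfonyl, so for compound 3 no step beyond the scatter is expected in this assay, in either direction. Compound 3 is therefore estimated at 3500 nM, with a range of 1200 nM to 10000 nM. This expected shift, a 1.3-fold higher number from compound 1 to compound 3 (0.13 log units; within the scatter), would be within the scatter.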

Compound 3, half-maximal inhibitory concentration: 510 nM
Compound 3: middle estimate off by 6.9-fold (0.84 log units), on the high side; the measured number lies below the stated range.
By their numbers in this assay, from the lowest: compound 3; then compounds 1 and 2 (each within the scatter of the next).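

In this assay, this aromatic carbon of the core of compound 1 tolerates more than a neutral outcome: the ((trifluoromethyl)sulfonyl)carbamoyl group gives a 5.1-fold lower number from compound 1 to compound 3 (0.71 log units; beyond the scatter) and so moves the number beyond the scatter, which the phenyl analogue did not do. The group on the sulfonyl sulfur therefore decides the result, with trifluoromethyl in place of phenyl giving a 9.2-fold lower number from compound 2 to compound 3 (0.96 log units; beyond the scatter) while the carbamoyl and sulfonyl parts stay the same. Nothing at hand explains why these two sulfonyl substituents differ.

On these data alone, it remains open whether the gain is specific to trifluoromethyl or would also appear with a methyl, a longer perfluoroalkyl chain or a fluorinated phenyl on the sulfur. Also open, as far as these compounds go, is whether a simple carboxylic acid on the same aromatic carbon would match the ((trifluoromethyl)sulfonyl)carbamoyl group.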